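The source may report more compounds than this note shows. Statements on the series, on what has been measured and on what is new or still open speak of the compounds shown alone.

Compound 1 `O=C1/C(=C\c2ccc(F)cc2)c2ccccc2N1c1c(Cl)cccc1Cl` gives 8 ug/mL in a functional assay on HuTu80 cells (Homo sapiens) for cytotoxicity, read by MTT assay, with a stated time of 72 h; on this read-out higher numbers stand for an effect only at larger amounts of compound and lower numbers for an effect already at smaller amounts. Compound 2 `O=C1/C(=C\c2ccccc2[N+](=O)[O-])c2ccccc2N1c1c(Cl)cccc1Cl` gives 10 ug/mL in this assay; the step of a 1.3-fold higher number from compound 1 to compound 2 (0.10 log units; within the scatter) shows that exchanging the aryl group on the double-bonded chain carbon left the read-out essentially unchanged. Within the data shown here, compound 2 and compound 1 therefore stand within the scatter of each other, and no other compound has yet been measured in this assay.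

Compound 3 `O=C1/C(=C\c2ccccc2Cl)c2ccccc2N1c1c(Cl)cccc1Cl` differs from compound 2 by chloro in place of nitro on an aromatic carbon. Among the measured compounds shown here, the only measured step that bears on this change is a 1.3-fold higher number from compound 1 to compound 2 (0.10 log units; within the scatter), which also altered the substituent on the same aryl ring and stayed within the scatter. On this basis compound 3 is expected to show a step of about no change at the digits printed from compound 2 to compound 3 (within the scatter), that is, nothing beyond the scatter. The value of compound 3 in this assay is accordingly estimated at 10 ug/mL, with a plausible range from 4 ug/mL to 25 ug/mL.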

Compound 3, concentration for half-maximal effect: > 100 ug/mL
Compound 3 gave a limit, no number; the forecaster's own chance of this, stated with the estimate: 5%; middle value at least 10-fold (1.00 log units) from the limit.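

In this assay, compound 3 gives a limit and not a number: the limit of > 100 ug/mL in this assay, at which 1 of the 3 values shown sits. The step of an at least 10-fold higher number from compound 2 to compound 3 (1.00 log units; beyond the scatter) shows that, on this aromatic carbon ortho to a large group, chloro in place of nitro is not a neutral exchange, although the earlier aryl change, a 1.3-fold higher number from compound 1 to compound 2 (0.10 log units; within the scatter), had stayed within the scatter. The step of an at least 12-fold higher number from compound 1 to compound 3 (1.09 log units; beyond the scatter) adds that the aryl group on the double-bonded chain carbon cannot be exchanged freely, since 2-chlorophenyl parts from 4-fluorophenyl where 2-nitrophenyl did not.

On these data alone, the true size of both new steps stays open, as each rests on a limit. Also open, as far as these compounds go, is whether an amine or a methoxy group on the same aromatic carbon would read like nitro or like chloro.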